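This account rests on a few compounds, and the source may have more. Where it says the series, first, only, none or still open, it means among the compounds named here.

Compounds measured so far in a functional assay on the whole organism (artery, strain albino) with Rattus norvegicus as the target, with a stated time of 300 min, at a dose of 10 mg/kg by the oral route; on this read-out higher numbers stand for more inhibition at the one dose given (going by the name of the read-out) and lower numbers for less inhibition:
compound 1 `COc1ccc(C2N=C(SCc3ccccc3)NC(C)=C2C(=O)Nc2ccc(F)cc2)cc1OC` gives 7.2%
compound 2 `COc1ccc(C2N=C(SCc3ccc(Cl)cc3)NC(C)=C2C(=O)Nc2ccc(F)cc2)cc1OC` gives 31.3%
compound 3 `CC1=C(C(=O)Nc2ccc(Br)cc2)C(c2ccc(Cl)cc2Cl)N=C(SCc2ccccc2)N1` gives 22.1%

Compound 1 and compound 2 share one core and differ by a single change, (chloro in place of hydrogen on an aromatic carbon), which made a step of a number 24.1 percentage points higher from compound 1 to compound 2 (beyond the scatter) in this assay. Compound 3 rests on a different core; how it differs from the core of compound 1 is not broken down here. Compound 4 `CC1=C(C(=O)Nc2ccc(Br)cc2)C(c2ccc(Cl)cc2Cl)N=C(SCc2ccccc2Cl)N1` carries the same kind of change relative to compound 3, (chloro in place of hydrogen on an aromatic carbon), but the place is not identical: in compound 2 the chloro sits para to a large group, in compound 4 ortho to a large group, so the two changes are of the same kind and not the same. Resting on the single earlier step of a number 24.1 percentage points higher from compound 1 to compound 2 (beyond the scatter) and on that shift in place, the expected step is a number 12.9 percentage points higher from compound 3 to compound 4 (beyond the scatter) in this assay. Compound 4 is accordingly estimated at 35% in this assay, expected to fall between 15% and 55%.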

Compound 4, a percentage reported as inhibition, in the whole organism at one dose (the size of the read-out at that dose, not a potency): 36.4%
Compound 4: middle estimate off by 1.4 percentage points, on the low side; the measured number falls inside the stated range.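

Replacing benzyl with 2-chlorobenzyl gave a number 14.3 percentage points higher from compound 3 to compound 4 (beyond the scatter) in this assay. Chloro in place of hydrogen raised the number on both cores, and the two steps do not differ by more than repeated measurements allow: the same change on two cores in this assay, a number 24.1 percentage points higher (beyond the scatter) from compound 1 to compound 2 and a number 14.3 percentage points higher (beyond the scatter) from compound 3 to compound 4, 9.8 percentage points apart, within the scatter of two such steps. This shows the gain carrying over between these two cores only, with the chloro in a different place on each, so it neither shows that the step would hold on other cores nor separates the influence of place from that of core.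

The compounds shown leave open how fluoro, methoxy or a nitrile would fare in place of this chloro. They also leave open whether an amine or a longer chain in place of the benzyl group would keep the number up.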